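The compounds below may be only part of what the source reports. "The series", "measured", "known", "first", "only" and "open" are said of these compounds alone.

Compound 2 `COc1ccc(CNc2cc(OC)c(OC)c(OC)c2)cc1Br` stands second highest among the three numbers measured in a functional assay on KYSE-450 cells (Homo sapiens) for inhibition, read by MTT assay, with a stated time of 48 h (on this read-out higher numbers stand for weaker inhibition and lower numbers for stronger inhibition), where compound 2 gives 39800 nM. Among the measured compounds shown here, its nearest neighbour is compound 1 `COc1ccc(CNc2cc(OC)c(OC)c(OC)c2)cc1C`, which in this assay gives 73800 nM; the only single-point step among the measured compounds, a 1.9-fold lower number from compound 1 to compound 2 (0.27 log units; within the scatter), joins these two. Far away stands compound 3 `COc1ccc(CN(C(=O)CCCl)c2cc(OC)c(OC)c(OC)c2)cc1O`, which carries an additional acyl group and in this assay gives 110 nM.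

Compound 4 `COC(=O)c1cc(CNc2cc(OC)c(OC)c(OC)c2)ccc1OC` has not yet been measured. It differs from compound 2 in one place: methoxycarbonyl in place of bromo on an aromatic carbon.

For the measured compounds named here, no measured step shows this exact exchange. Going by the values given here, the one step that does exist, a 1.9-fold lower number from compound 1 to compound 2 (0.27 log units; within the scatter), swaps one small group for another on the same aromatic carbon and stays within the scatter, so a further exchange at that position gives little ground to expect a large move. The wide gap between compound 2 and compound 3 accompanies a change elsewhere in the molecule, which compound 4 does not share. For compound 4 in this assay the expected step is therefore a 1.0-fold higher number from compound 2 to compound 4 (0.00 log units; within the scatter), nothing beyond the scatter. Compound 4 is estimated at 40000 nM, within 10000 nM to 160000 nM.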

Compound 4, half-maximal inhibitory concentration: 41100 nM
Compound 4: middle estimate off by 1.0-fold (0.01 log units), on the low side; measured number inside the range.
By their numbers in this assay, from the lowest: compound 3; then compounds 2, 4 and 1 (each within the scatter of the next).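

At this aromatic carbon, ortho to a methoxy group, methoxycarbonyl brings four heavy atoms and two hydrogen-bond acceptors where bromo had one heavy atom and none, yet this assay shows a 1.0-fold higher number from compound 2 to compound 4 (0.01 log units; within the scatter) and, against the methyl group, a 1.8-fold lower number from compound 1 to compound 4 (0.25 log units; within the scatter). The earlier compounds shown here compared only methyl and bromo, so the result widens the comparison to a larger group with a carbonyl, and compound 1, compound 2 and compound 4 all remain within the scatter of one another. Nothing at hand explains why such different groups give such similar numbers in this assay.

From the compounds shown here alone, whether a carboxylic acid or an amine at this carbon would also leave the number within the scatter remains open. Compound 3 differs from these compounds both in its hydroxy group at this carbon and in its additional acyl group, so the compounds shown cannot say how much of its far lower number belongs to either change, or whether a hydroxy group alone would move the number at all.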